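Swapping the Anilino Ring: Bromine Out, Ethyl In

The source may report more compounds than this note shows. Statements on the series, on what has been measured and on what is new or still open speak of the compounds shown alone.

Compound 1, `O=C(CSc1nc(Nc2ccccc2)c2ccccc2n1)Nc1ccc(Cl)cc1`, gives 17200 nM.
Compound 2, `O=C(CSc1nc(Nc2ccccc2)c2ccccc2n1)Nc1ccc(Cl)cc1Cl`, gives 19400 nM.
Compound 3, `C=CC(=O)Nc1cccc(NC(=O)CSc2nc(Nc3ccccc3Br)c3ccccc3n2)c1`, gives 15200 nM.

These three compounds were tested in a functional assay on MDA-MB-231 cells (Homo sapiens) for inhibition, read by MTT assay, with a stated time of 72 h; a lower number here means a stronger inhibitor, a higher number a weaker inhibitor. Their numbers lie close together: the gap between compound 3 and compound 1, and the gap between compound 3 and compound 2, each fall within the usual scatter of repeated measurements, so none of the three can be called stronger or weaker than the others on this evidence.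

Within the data shown here, only one pair differs in a single place. The step of a 1.1-fold higher number from compound 1 to compound 2 (0.05 log units; within the scatter) adds a chloro group on the anilide ring and leaves the number essentially unchanged.

Compound 4, `C=CC(=O)Nc1cccc(NC(=O)CSc2nc(Nc3ccc(CC)cc3)c3ccccc3n2)c1`, has not yet been measured. It differs from compound 3 at the other end of the molecule: 4-ethylphenyl in place of 2-bromophenyl on a nitrogen on an aromatic ring. Among the measured compounds shown here, no measured pair changes this ring, so the one step on record bears only loosely on it, and it was flat. With nothing pointing either way, the expectation is a step of a 1.0-fold lower number from compound 3 to compound 4 (0.01 log units; within the scatter) that stays within the scatter. Compound 4 is therefore estimated at 15000 nM, with a plausible range from 6000 nM to 40000 nM.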

Compound 4, half-maximal inhibitory concentration: 14400 nM
The estimate for compound 4 lay 1.0-fold (0.02 log units) above the measured number; the measured number falls inside the stated range.
By their numbers in this assay, from the lowest: compounds 4, 3, 1 and 2 (each within the scatter of the next).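

Replacing 2-bromophenyl with 4-ethylphenyl on a nitrogen on an aromatic ring gives a 1.1-fold lower number from compound 3 to compound 4 (0.02 log units; within the scatter) in this assay, so this position, untouched by the earlier step, now has a step of its own, and that step is flat. The change alters both the kind of group and its numbered place on the ring, so this flat result does not show that either change alone would also be flat. No measured property on hand accounts for this step.

The compounds shown leave open whether an amine or a carboxylic acid on this ring, or a longer chain in place of ethyl, would carry the number beyond the scatter, and whether a bromine and an ethyl group would match if each sat at the other's numbered place. The acrylamide-bearing side also remains unread, since compound 3 and compound 1 differ in more than one place and no single change connects that side with the chlorophenyl amides.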